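This account rests on a few compounds, and the source may have more. Where it says the series, first, only, none or still open, it means among the compounds named here.

Compound 2 `Cc1ccc(N(C)S(=O)(=O)C2CC3OC2C(c2ccc(NC(=O)CCCCCCC(=O)O)cc2)=C3c2ccc(O)cc2)cc1` stands at the lowest of the three numbers shown in a functional assay on MCF7 cells (Homo sapiens) for antiproliferative activity, read by MTT assay, with a stated time of 72 h (on this read-out higher numbers stand for weaker inhibition and lower numbers for stronger inhibition), giving 23200 nM. Compound 1 `CN(c1ccccc1)S(=O)(=O)C1CC2OC1C(c1ccc(NC(=O)CCCCCCC(=O)O)cc1)=C2c1ccc(O)cc1` gives 63800 nM, and compound 3 `CCN(c1cccc(C)c1)S(=O)(=O)C1CC2OC1C(c1ccc(NC(=O)CCCCCCC(=O)O)cc1)=C2c1ccc(O)cc1` gives 31800 nM; the step of a 2.8-fold lower number from compound 1 to compound 2 (0.44 log units; beyond the scatter) lies beyond the scatter. Compound 4 `CCN(c1ccccc1Cl)S(=O)(=O)C1CC2OC1C(c1ccc(NC(=O)CCCCCCC(=O)O)cc1)=C2c1ccc(O)cc1` differs from compound 2 in one place: (2-chlorophenyl)(ethyl)amino in place of methyl(4-methylphenyl)amino on a sulfonyl sulfur. Two measured steps alter the same amino group on the sulfonyl sulfur, a 2.0-fold lower number from compound 1 to compound 3 (0.30 log units; within the scatter) and a 1.4-fold higher number from compound 2 to compound 3 (0.14 log units; within the scatter), and both lie within the scatter. No step beyond the scatter is therefore expected in this assay for compound 4, the estimated step being a 1.2-fold higher number from compound 2 to compound 4 (0.08 log units; within the scatter). Compound 4 is estimated at 28000 nM, with a range from 12000 nM to 65000 nM.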

Compound 4, half-maximal inhibitory concentration: 33300 nM
Compound 4: the middle estimate sits 1.2-fold (0.08 log units) below what was measured; low and high end bracket the measured number.
By their numbers in this assay, from the lowest: compounds 2, 3, 4 and 1 (each within the scatter of the next, the first and the last beyond it).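

In this assay, going by these compounds alone, chlorine appears for the first time in the amino group on the sulfonyl sulfur, and the number stays within the scatter of all three earlier compounds (a 1.4-fold higher number from compound 2 to compound 4 (0.16 log units; within the scatter); a 1.0-fold higher number from compound 3 to compound 4 (0.02 log units; within the scatter); a 1.9-fold lower number from compound 1 to compound 4 (0.28 log units; within the scatter)). A 2-chlorophenyl on the sulfonamide nitrogen therefore cannot be told apart from a 3-methylphenyl there. Nothing given here accounts for this result. The compounds shown leave open whether a pyridine ring on that nitrogen, or a hydrogen in place of its ethyl, would move the number beyond the scatter.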